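Swapping the sulfonyl aryl group: isopropyl out, fluorine in

A few compounds are considered here, and "the series" means these few. Any claim that something is new, unique, unknown or untested is made for them only; others in the source may bear on it.

Among the compounds with values here, compound 2 `CC(C)c1ccc(S(=O)(=O)c2ccc3[nH]nc(C4CCN(C)CC4)c3c2)cc1` gives the lowest of the two numbers so far in an assay on HeLa cells for displacement of a labelled ligand from 5-hydroxytryptamine receptor 6 (Homo sapiens) (on this read-out higher numbers stand for weaker inhibition and lower numbers for stronger inhibition), namely 14 nM. Within the data shown here, its only measured neighbour, compound 1 `CN1CCC(c2n[nH]c3ccc(S(=O)(=O)c4ccccc4)cc23)CC1`, gives 55 nM in this assay, and the step of a 3.9-fold lower number from compound 1 to compound 2 (0.59 log units; beyond the scatter) shows that an isopropyl in place of hydrogen on an aromatic carbon shifted the number well beyond the scatter. Compound 3 `CN1CCC(c2n[nH]c3ccc(S(=O)(=O)c4cccc(F)c4)cc23)CC1` has not yet been measured. It differs from compound 2 by 3-fluorophenyl in place of 4-isopropylphenyl on a sulfonyl sulfur. Among the measured compounds shown here, no measured step covers a fluorine on this ring, so the only guides are the phenyl of compound 1, which gave 55 nM, and the isopropyl step. Because a 3.9-fold lower number from compound 1 to compound 2 (0.59 log units; beyond the scatter) came from the isopropyl alone, removing it is expected to undo much of that step, with the fluorine adding an uncertain smaller shift. Compound 3 is therefore expected to move back toward the weaker end, by a 2.9-fold higher number from compound 2 to compound 3 (0.46 log units; beyond the scatter). Compound 3 is estimated at 40 nM, with a range from 15 nM to 110 nM.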

Compound 3, inhibition constant: 93 nM
Compound 3: the middle estimate sits 2.3-fold (0.37 log units) below what was measured; the range from low to high includes it.
By their numbers in this assay, from the lowest: compound 2; then compounds 1 and 3 (each within the scatter of the next).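

In this assay, exchanging the 4-isopropylphenyl on the sulfonyl sulfur for 3-fluorophenyl gives a 6.6-fold higher number from compound 2 to compound 3 (0.82 log units; beyond the scatter), so the low number of compound 2 does not carry over to this aryl group. Fluoro in place of hydrogen on an aromatic carbon gives a 1.7-fold higher number from compound 1 to compound 3 (0.23 log units; within the scatter), so this fluorine cannot be told apart from the plain phenyl. Of the three aryl groups, only 4-isopropylphenyl stands clearly apart from the other two, which shows that a substituent on this ring does not always shift the number. Nothing available here explains why these groups differ.

Fluorine and isopropyl differ in both identity and ring place, so the effect of ring place remains unresolved. As far as these compounds go, how a methoxy group or an amine on this ring would compare also remains open.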